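Replacing Hydroxymethyl With Isopropyl on the Amide Carbonyl

The compounds below may be only part of what the source reports. "The series", "measured", "known", "first", "only" and "open" are said of these compounds alone.

Compound 1, `COCC(=O)N(Cc1ccc(OC)c(O)c1)c1cc(OC)c(OC)c(OC)c1`: 230 nM
Compound 2, `C=C(C)C(=O)N(Cc1ccc(OC)c(O)c1)c1cc(OC)c(OC)c(OC)c1`: 200 nM
Compound 3, `COc1ccc(CN(C(=O)CO)c2cc(OC)c(OC)c(OC)c2)cc1O`: 520 nM

These three share one core and differ only in the group on the carbonyl carbon. In a functional assay on HCT-116 cells (Homo sapiens) for inhibition, read by MTT assay, with a stated time of 48 h (a lower number here means a stronger inhibitor, a higher number a weaker inhibitor), compound 3 gives the highest number of the three: the step of a 2.3-fold higher number from compound 1 to compound 3 (0.35 log units; beyond the scatter) and the step of a 2.6-fold higher number from compound 2 to compound 3 (0.41 log units; beyond the scatter) are both modest yet beyond the scatter, while a 1.2-fold lower number from compound 1 to compound 2 (0.06 log units; within the scatter) lies within it. Compound 4, `COc1ccc(CN(C(=O)C(C)C)c2cc(OC)c(OC)c(OC)c2)cc1O`, is not yet measured. The change is isopropyl in place of hydroxymethyl on a carbonyl carbon. Both steps toward compound 3 bear on it, since each produced hydroxymethyl and raised the number modestly; the move to isopropyl removes that group again, so compound 4 is expected to show a modest drop, a 2.3-fold lower number from compound 3 to compound 4 (0.35 log units; beyond the scatter). Compound 4 is therefore estimated at 230 nM, within 110 nM to 480 nM.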

Compound 4, half-maximal inhibitory concentration: 310 nM
The estimate for compound 4 lay 1.3-fold (0.13 log units) below the measured number; low and high end bracket the measured number.
By their numbers in this assay, from the lowest: compounds 2, 1, 4 and 3 (each within the scatter of the next, the first and the last beyond it).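

In this assay, isopropyl on the carbonyl carbon cannot be told apart from hydroxymethyl (a 1.7-fold lower number from compound 3 to compound 4 (0.22 log units; within the scatter)), so removing hydroxymethyl does not give a clear gain here. Isopropyl also cannot be told apart from 1-methylethenyl (a 1.6-fold higher number from compound 2 to compound 4 (0.19 log units; within the scatter)) or methoxymethyl (a 1.3-fold higher number from compound 1 to compound 4 (0.13 log units; within the scatter)), which places compound 4 within the scatter of all three others and shows that this position tolerates these small groups with little separation. Nothing available here accounts for these numbers. Still open, as far as these compounds go, is how an amine, a carboxylic acid or a longer chain on this carbonyl carbon would behave in this assay.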